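Selenium Hydrogen in Place of Pentyl: Expected Cytotoxicity

This account rests on a few compounds, and the source may have more. Where it says the series, first, only, none or still open, it means among the compounds named here.

Measured compounds:
Compound 1 `COc1ccc(CNc2nc([SeH])nc3ccccc23)cc1`: in this assay compound 1 gives > 100000 nM, a limit of the assay rather than a number.
Compound 2 `CCCCC[Se]c1nc(NCc2ccc(SC)cc2)c2ccccc2n1`: compound 2 gives > 100000 nM, again a limit of the assay rather than a number.

Both known values were read in a functional assay on CCRF-CEM cells (Homo sapiens) for cytotoxicity, read by MTT assay, with a stated time of 72 h; a lower number here means that less compound is tolerated, a higher number that more compound is tolerated. Among the compounds with values here, compound 2 therefore stands at the edge of what the assay can report; the two values so far both sit there, as the evidence shows (the limit of > 100000 nM in this assay, at which 2 of the 2 values shown sit), so no real spread between the compounds is visible.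

Compound 3 `CSc1ccc(CNc2nc([SeH])nc3ccccc23)cc1` differs from compound 2 in one place: hydrogen in place of pentyl on a selenium. Within the data shown here, no measured pair separates the effect of this change, and with both known compounds at the limit there is no basis to expect a step beyond the scatter. The step from compound 2 to compound 3 is expected to be about a number no higher from compound 2 to compound 3 (the limit leaves the size open). Compound 3 is therefore estimated at 100000 nM, within a range from 30000 nM to 300000 nM, most likely again reported only as a limit.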

Compound 3, concentration lethal to 50% of the cells: > 100000 nM
Compound 3: only a limit was reported; the forecaster's own chance of this, stated with the estimate: 80%; the middle value lies on the limit itself.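

No step from compound 1 or compound 2 to compound 3 can be read, because all three compounds give a limit rather than a number: the limit of > 100000 nM in this assay, at which 3 of the 3 values shown sit.

The compounds shown leave open whether hydrogen in place of pentyl, or methylsulfanyl in place of methoxy, changes cytotoxicity at all.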